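The source may report more compounds than this note shows. Statements on the series, on what has been measured and on what is new or still open speak of the compounds shown alone.

Working notes on the series. In a functional assay on SK-MEL-28 cells (Homo sapiens) for cytotoxicity, read by MTT assay, with a stated time of 72 h (on this read-out higher numbers stand for weaker inhibition and lower numbers for stronger inhibition), compound 2 `CCOC(=O)c1sc(N2CCCC2)nc1Cl` gives 82000 nM and compound 3 `O=C(c1ccccc1)c1sc(N2CCCC2)nc1Cl` gives 98000 nM, so compound 2 stands within the scatter of compound 3. Compound 1 `CSc1nc(Cl)c(C(=O)c2ccccc2)s1` gives > 100000 nM, which is a limit of the assay and not a number.

Compound 4 `N#Cc1sc(N2CCCC2)nc1Cl` is derived from compound 2 by one change, with cyano in place of ethoxycarbonyl on an aromatic carbon.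

For the measured compounds named here, two measured steps bear on this. The closer one swaps phenyl for ethoxy on the carbonyl carbon of the same group and gives a 1.2-fold higher number from compound 2 to compound 3 (0.08 log units; within the scatter). The other swaps pyrrolidin-1-yl for methylsulfanyl on an aromatic carbon and gives an at least 1.0-fold lower number from compound 1 to compound 3 (0.00 log units; that floor lies within the scatter). Going by the values given here, neither step goes beyond the scatter, though no measured step removes the whole ethoxycarbonyl group, so the support is indirect.

As far as these compounds go, on this basis, no step beyond the scatter is expected in this assay, and the direction stays open. The expected step is a 1.1-fold lower number from compound 2 to compound 4 (0.04 log units; within the scatter). For compound 4 the estimated value is 75000 nM, with an expected range of 25000 nM to 130000 nM.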

Compound 4, half-maximal inhibitory concentration: > 100000 nM
Compound 4 was reported as a limit; the forecaster's own chance of this, stated with the estimate: 30%; middle value at least 1.3-fold (0.12 log units) from the limit.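

In this assay compound 4 gives > 100000 nM, which is a limit of the assay and not a number. The earlier step at this position, on the aromatic carbon next to the ring sulfur, only exchanged ethoxy for phenyl on the carbonyl carbon, whereas this change removes the whole ethoxycarbonyl group, carbonyl included, and puts cyano in its place, which gives an at least 1.2-fold higher number from compound 2 to compound 4 (0.08 log units; that floor lies within the scatter). So the carbonyl is not needed to keep the number at the level of compound 2 or weaker, no stronger inhibition appears with the smaller group, and the true size of the step cannot be read past its floor: the limit of > 100000 nM in this assay, at which 2 of the 4 values shown sit.

As far as these compounds go, whether any group on this carbon can move the number beyond the scatter stays open, and a carboxylic acid or a primary carboxamide in place of cyano would bear on that question. Equally open, from the compounds shown here alone, is whether a longer chain on the ester oxygen, or a morpholine in place of the pyrrolidin-1-yl group, would bring the series clear of the limit at all.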